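The source may hold more compounds than are shown below. What is called first, only, known or untested is meant among the compounds shown, and "the series" means these compounds.

Values measured in a physicochemical assay for lipophilicity, read by HPLC, using the shake flask method; a lower number here means a more polar compound, a higher number a more lipophilic compound:

- compound 1 `CCCCCN(Cc1ccc(Cl)nc1)/C(C)=N/C#N`: 2.37
- compound 2 `CCCC/C(=N\C#N)N(C)Cc1ccc(Cl)nc1`: 1.87

Compound 1 holds the higher of these two numbers, and compound 2 lies below it by more than the usual scatter of repeated measurements. These two compounds differ in more than one place, so their gap does not isolate any single structural change.

Compound 3 `C/C(=N\C#N)NCc1ccc(Cl)nc1` has not yet been measured in this assay. It departs from compound 1 by one change, hydrogen in place of pentyl on an amine nitrogen. For the measured compounds named here, no measured pair here shows this change, so the expectation is a judgement based on the size of the group that leaves. A large move towards lower numbers is expected, well beyond the scatter, and the expected size is a number 1.67 log units lower from compound 1 to compound 3 (beyond the scatter). For compound 3 the estimated value is 0.7, with an expected range from 0.3 to 1.2.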

Compound 3, partition coefficient: 1.07
The estimate for compound 3 lay 0.37 log units below the measured number; the measured number falls inside the stated range.
By their numbers in this assay, from the lowest: compound 3; then compound 2; then compound 1.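

For the compounds shown here, replacing pentyl with hydrogen on the amine nitrogen gives the first step here that changes one place only, and in this assay it reads a number 1.30 log units lower from compound 1 to compound 3 (beyond the scatter) as a large move. Unlike the gap between the first two compounds, this step can be assigned to a single change, since the rest of the core of compound 1 stays the same. Nothing shown here accounts for the size of this step.

The compounds shown leave open how the number would respond to an ethyl or a propyl chain on this nitrogen, so it is unknown whether it would change steadily with chain length. They also leave open how a chain ending in an amine or a carboxylic acid would compare with pentyl at this place.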